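Notes on replacing phenyl in compound 3

The source may report more compounds than this note shows. Statements on the series, on what has been measured and on what is new or still open speak of the compounds shown alone.

Measured in an ADME assay on the whole organism (Mus musculus, strain CD-1) for pharmacokinetics; a higher number here means faster removal of the compound, a lower number slower removal:
- compound 1 `COc1cc([C@](O)(CCN(C)C)[C@@H](c2cc3cc(Br)ccc3nc2OC)c2cccc(OC)c2F)cc(OC(F)F)n1`: 9.7 mL/min/kg
- compound 2 `COc1cccc([C@H](c2cc3cc(Br)ccc3nc2OC)[C@@](O)(CCN(C)C)c2cc(SC)nc(SC)c2)c1F`: 13 mL/min/kg
- compound 3 `CCSc1cc([C@](O)(CCN(C)C)[C@H](c2ccccc2)c2cc3cc(Br)ccc3nc2OC)cc(SCC)n1`: 11 mL/min/kg

Compound 3 sits within the scatter of both compound 1 and compound 2, so the three values show no order in this assay. Next in line is compound 4 `CCSc1cc([C@](O)(CCN(C)C)[C@@H](c2cc3cc(Br)ccc3nc2OC)c2cccc(OC)c2F)cc(SCC)n1`, with this change from compound 3: 2-fluoro-3-methoxyphenyl in place of phenyl on a saturated chain carbon bound to an aromatic carbon and a saturated chain carbon. In words, 2-fluoro-3-methoxyphenyl stands in place of phenyl on a saturated chain carbon bound to an aromatic carbon and a saturated chain carbon.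

Going by the values given here, no measured step covers this exchange directly. Among the compounds with values here, the only step available, a 1.3-fold higher number from compound 1 to compound 2 (0.13 log units; within the scatter), lies at a different place in the structure and stays within the scatter. Indirect support comes from the values: compound 2 carries 2-fluoro-3-methoxyphenyl and gives 13 mL/min/kg, while compound 3 carries phenyl and gives 11 mL/min/kg, and these two lie within the scatter of each other. The expected result is therefore no change beyond the scatter, with an estimated no change at the digits printed from compound 3 to compound 4 (within the scatter). For compound 4 the expected clearance is 11 mL/min/kg, within an estimated range of 6 mL/min/kg to 20 mL/min/kg.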

Compound 4, clearance: 3.6 mL/min/kg
Beside the measured number, compound 4's estimate is 3.1-fold (0.49 log units) above it, and the stated range ends above it.
By their numbers in this assay, from the lowest: compound 4; then compounds 1, 3 and 2 (each within the scatter of the next).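

In this assay, 2-fluoro-3-methoxyphenyl in place of phenyl on a saturated chain carbon bound to an aromatic carbon and a saturated chain carbon gives a 3.1-fold lower number from compound 3 to compound 4 (0.49 log units; beyond the scatter), the first step shown at this position. With 2-fluoro-3-methoxyphenyl held constant, the group of 12 heavy atoms with two sulfurs on the saturated chain carbon bound to an oxygen on a saturated carbon and two saturated chain carbons also gives steps beyond the scatter, a 3.6-fold lower number from compound 2 to compound 4 (0.56 log units; beyond the scatter) and a 2.7-fold lower number from compound 1 to compound 4 (0.43 log units; beyond the scatter), so both places can move this read-out. Nothing measured here accounts for these steps.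

Still open, as far as these compounds go, is how 2-fluorophenyl or 3-methoxyphenyl alone would compare at this position, as the fluorine and the methoxy are not separated. Also open, from the compounds shown here alone, is whether phenyl in place of 2-fluoro-3-methoxyphenyl would give a similar step alongside the other groups, those of compound 1 and compound 2.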